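This account rests on a few compounds, and the source may have more. Where it says the series, first, only, none or still open, it means among the compounds named here.

Measured so far:

compound 1, `COc1cc(Cc2nc3c(N)ncnc3n2CC2CCCCC2)cc(OC)c1OC` — 39800 nM
compound 2, `COc1cc(Cc2nc3c(N)ncnc3n2CCCC(C)C)cc(OC)c1OC` — 69200 nM
compound 3, `COc1cc(Cc2nc3c(N)ncnc3n2CC2CCC2)cc(OC)c1OC` — 45700 nM

All three share one core and differ only in the group on the saturated chain carbon bound to the aromatic nitrogen. In a functional assay on MCF7 cells (Homo sapiens) for antiproliferative activity (a lower number here means a stronger inhibitor, a higher number a weaker inhibitor), compound 1 gives 39800 nM, the lowest of the three numbers, yet its nearest neighbour compound 3 sits only a 1.1-fold higher number from compound 1 to compound 3 (0.06 log units; within the scatter) and the furthest, compound 2, only a 1.7-fold higher number from compound 1 to compound 2 (0.24 log units; within the scatter); compound 2 to compound 3 reads a 1.5-fold lower number from compound 2 to compound 3 (0.18 log units; within the scatter). Nothing among these three separates one from another.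

Compound 4, `COCCn1c(Cc2cc(OC)c(OC)c(OC)c2)nc2c(N)ncnc21`, has not yet been measured in this assay. Against compound 1 the change is methoxymethyl in place of cyclohexyl on a saturated chain carbon bound to an aromatic nitrogen. The measured steps that bear on it are the two swaps at the same place, cyclohexyl to isopentyl and cyclohexyl to cyclobutyl, both within the scatter. Methoxymethyl is smaller than any of those groups and carries one hydrogen-bond acceptor, which none of the measured groups does, so the data give no direct precedent for it; they show only that this position tolerates change without moving the number.

Compound 4 is therefore expected to land near compound 1, at roughly a 1.3-fold higher number from compound 1 to compound 4 (0.10 log units; within the scatter), with the estimate for compound 4 at 50000 nM and a range from 20000 nM to 150000 nM.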

Compound 4, half-maximal inhibitory concentration: 64600 nM
Compound 4: middle estimate off by 1.3-fold (0.11 log units), on the low side; low and high end bracket the measured number.
By their numbers in this assay, from the lowest: compounds 1, 3, 4 and 2 (each within the scatter of the next).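

In this assay, methoxymethyl in place of cyclohexyl on a saturated chain carbon bound to an aromatic nitrogen gives a 1.6-fold higher number from compound 1 to compound 4 (0.21 log units; within the scatter) and stays there even though the entering group has no ring, has fewer heavy atoms than cyclohexyl and carries a hydrogen-bond acceptor. The same group set against cyclobutyl gives a 1.4-fold higher number from compound 3 to compound 4 (0.15 log units; within the scatter) and, cut one bond further out, methoxy in place of isobutyl gives a 1.1-fold lower number from compound 2 to compound 4 (0.03 log units; within the scatter) and likewise stays within the scatter, so the only group shown with a hydrogen-bond acceptor cannot be told apart from the three groups of carbon and hydrogen alone. No measurement is at hand that could explain this tolerance.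

Going by these compounds, whether an amine, a carboxylic acid or a longer chain at this place would also stay within the scatter remains open, and so does whether any group here can move the number beyond it. The rest of the shared core is the same in all four compounds, so these results say nothing about what a change elsewhere on it would do.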